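The compounds below may be only part of what the source reports. "The series", "measured", "known", "first", "only" and "open" are said of these compounds alone.

In an in vitro ADME assay on microsomes from liver (Homo sapiens) for metabolic stability (on this read-out lower numbers stand for slow clearance and higher numbers for fast clearance), compound 2 `O=C(COCc1ccccn1)N1CCN(c2ccc(Cl)cc2Cl)CC1` stands at 94 mL.min-1.g-1 as the higher of the two numbers, and compound 1 `O=C(COCc1ccncc1)N1CCN(c2ccc(Cl)cc2)CC1` stands at 17 mL.min-1.g-1 on this read-out. The gap between these two numbers lies beyond the scatter. Compound 3 `O=C(COCc1ncccn1)N1CCN(c2ccc(Cl)cc2Cl)CC1` differs from compound 2 by pyrimidin-2-yl in place of pyridin-2-yl on a saturated chain carbon bound to an oxygen on a saturated carbon with pyrimidin-2-yl in place of pyridin-2-yl on a saturated chain carbon bound to an oxygen on a saturated carbon. Within the data shown here, no measured pair isolates this change, so the direction rests on judgement alone. The expected step is a small fall, a 1.9-fold lower number from compound 2 to compound 3 (0.27 log units; within the scatter) by estimate. For compound 3 the estimate is 50 mL.min-1.g-1 with an expected range from 22 mL.min-1.g-1 to 105 mL.min-1.g-1 as the likely span.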

Compound 3, intrinsic clearance in microsomes: 16 mL.min-1.g-1
Compound 3: middle estimate off by 3.1-fold (0.49 log units), on the high side; measured number below the stated range.
By their numbers in this assay, from the lowest: compounds 3 and 1 (each within the scatter of the next); then compound 2.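

In this assay, pyrimidin-2-yl in place of pyridin-2-yl on a saturated chain carbon bound to an oxygen on a saturated carbon gives a 5.9-fold lower number from compound 2 to compound 3 (0.77 log units; beyond the scatter) with the rest of the structure unchanged. Among these compounds, this is the first step at this position that isolates one change, and it shows that clearance on this read-out responds to the ring held there. Nothing available here gives a reason for this step.

From the compounds shown here alone, whether pyrazin-2-yl or a morpholine at this place would give a similar number remains open. Also open, going by these compounds, is whether the step carries over to the chlorine pattern of compound 1.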